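Aryl for cycloalkyl at the ortho position of the benzylamide

The source may hold more compounds than are shown below. What is called first, only, known or untested is meant among the compounds shown, and "the series" means these compounds.

Compounds measured so far in an assay on CHO cells for antagonist activity at transient receptor potential cation channel subfamily V member 1 (Homo sapiens), read by FLIPR; on this read-out higher numbers stand for weaker inhibition and lower numbers for stronger inhibition:
compound 1, `CC(C)CCOc1cc(C(F)(F)F)ccc1CNC(=O)C(C)c1ccc(NS(C)(=O)=O)c(F)c1`, gives 0.5 nM
compound 2, `CC(C)CCSc1cc(C(F)(F)F)ccc1CNC(=O)C(C)c1ccc(NS(C)(=O)=O)c(F)c1`, gives 1.4 nM
compound 3, `CC(C(=O)NCc1ccc(C(F)(F)F)cc1C1CCCCC1)c1ccc(NS(C)(=O)=O)c(F)c1`, gives 0.6 nM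

Compound 3 stands second highest of the three numbers in this assay. Its nearest neighbour is compound 1, with a 1.2-fold higher number from compound 1 to compound 3 (0.08 log units; within the scatter), a gap within the scatter; the furthest is compound 2, with a 2.3-fold lower number from compound 2 to compound 3 (0.37 log units; beyond the scatter), a modest step beyond the scatter. Going by the values given here, the one step beyond the scatter so far, a 2.8-fold higher number from compound 1 to compound 2 (0.45 log units; beyond the scatter), concerns the exchange of an oxygen-linked for a sulfur-linked isopentyl chain and says nothing direct about ring replacements.

The next compound is compound 4, `CC(C(=O)NCc1ccc(C(F)(F)F)cc1-c1cccnc1)c1ccc(NS(C)(=O)=O)c(F)c1`. It differs from compound 3 by pyridin-3-yl in place of cyclohexyl on an aromatic carbon. Among the compounds with values here, no measured pair exchanges a saturated ring for an aromatic ring at this position, so the steps on hand bear on it only loosely: they show that this position tolerates an alkoxy chain, a thioether chain and a cyclohexyl ring with, at most, modest movement in this assay. A step of similar modest size, most likely toward a somewhat higher number, is expected for compound 4, as a 2.5-fold higher number from compound 3 to compound 4 (0.40 log units; beyond the scatter). The estimate for compound 4 in this assay is 1.5 nM, within a range from 0.5 nM to 5 nM.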

Compound 4, inhibition constant: 59.4 nM
The estimate for compound 4 lay 40-fold (1.60 log units) below the measured number, and the stated range ends below it.
By their numbers in this assay, from the lowest: compounds 1 and 3 (each within the scatter of the next); then compound 2; then compound 4.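

In this assay, this position proves far less permissive than the isopentyloxy, isopentylsulfanyl and cyclohexyl groups suggested: pyridin-3-yl gives a 99-fold higher number from compound 3 to compound 4 (2.00 log units; beyond the scatter), and the gap is also large against the two chains, with a 120-fold higher number from compound 1 to compound 4 (2.07 log units; beyond the scatter) and a 42-fold higher number from compound 2 to compound 4 (1.63 log units; beyond the scatter). Cyclohexyl and pyridin-3-yl have the same heavy-atom count, so that count alone does not separate compound 3 from compound 4; what changes is a non-aromatic ring of carbon only for an aromatic ring carrying one nitrogen and one hydrogen-bond acceptor. No supporting data are available to show which of these differences accounts for the loss.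

The compounds shown leave open whether the aromatic ring or its nitrogen carries the step, a question that a plain phenyl ring at this aromatic carbon would address directly. They also leave open whether the place of the nitrogen matters, as pyridin-2-yl and pyridin-4-yl would show, and whether a saturated ring containing nitrogen, such as piperidin-1-yl, would stay close to cyclohexyl or follow pyridin-3-yl.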